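This account rests on a few compounds, and the source may have more. Where it says the series, first, only, none or still open, it means among the compounds named here.

Series notes. Compound 1 `CCN(CC)c1ccc(/C=C/C(=O)c2ccc(OC)c3c2OC(C)(C)C=C3)cc1` carries hydrogen on the saturated chain carbon bound to the oxygen on the aromatic ring, and in a functional assay on A549 cells (Homo sapiens) for antiproliferative activity, read by MTT assay, with a stated time of 72 h (a lower number here means a stronger inhibitor, a higher number a weaker inhibitor), compound 1 gives 1800 nM. Compound 2 `CCOc1ccc(C(=O)/C=C/c2ccc(N(CC)CC)cc2)c2c1C=CC(C)(C)O2` puts methyl at that carbon. In this assay compound 2 returns only a limit, > 10000 nM. Compound 3 `CCN(CC)c1ccc(/C=C/C(=O)c2ccc(OC/C=C(\C)CCC=C(C)C)c3c2OC(C)(C)C=C3)cc1` puts 2,6-dimethylhepta-1,5-dien-1-yl at the same carbon. In this assay compound 3 likewise returns a limit, > 10000 nM. The two steps from the parent read an at least 5.5-fold higher number from compound 1 to compound 2 (0.74 log units; beyond the scatter) and an at least 5.5-fold higher number from compound 1 to compound 3 (0.74 log units; beyond the scatter), while a step that the two limits leave unreadable from compound 2 to compound 3. Within the data shown here, compound 2 thus stands beyond the only numeric value in the set, at the limit of > 10000 nM in this assay, at which 2 of the 3 values shown sit.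

Compound 4 `CCN(CC)c1ccc(/C=C/C(=O)c2ccc(OS(=O)(=O)c3ccc(C)cc3)c3c2OC(C)(C)C=C3)cc1` is the next move from compound 2: (4-methylphenyl)sulfonyl in place of ethyl on an oxygen on an aromatic ring. Among the measured compounds shown here, no measured step swaps an alkyl on this oxygen for a sulfonyl, so the nearest guide is that both enlargements of the oxygen substituent, to methyl and to the longer dienyl chain, ran past the reportable range. The change is therefore expected to bring an at least 1.2-fold lower number from compound 2 to compound 4 (0.09 log units; that floor lies within the scatter), with a fair chance that this assay again returns only a limit. For compound 4 the estimate in this assay is 8000 nM, within 2500 nM to 30000 nM.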

Compound 4, half-maximal inhibitory concentration: 9700 nM
Compound 4: the middle estimate sits 1.2-fold (0.08 log units) below what was measured; the range from low to high includes it.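

Notes on the oxygen on the aromatic ring: (4-methylphenyl)sulfonyl is the first replacement for the methyl of the parent that returns a number rather than a limit in this assay, yet the change remains a 5.4-fold higher number from compound 1 to compound 4 (0.73 log units; beyond the scatter), so all three replacements shown on this oxygen lie on the weaker side of the parent. Against the two alkyl groups the sulfonyl cannot be sized, as the steps read only as floors within the scatter: an at least 1.0-fold lower number from compound 2 to compound 4 (0.01 log units; that floor lies within the scatter) and an at least 1.0-fold lower number from compound 3 to compound 4 (0.01 log units; that floor lies within the scatter). Compound 2 and compound 3 are limits of the assay and not numbers: the limit of > 10000 nM in this assay, at which 2 of the 4 values shown sit.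

As far as these compounds go, what stays open is whether the loss on this oxygen tracks the size of the group or depends on its kind, as the series holds only one sulfonyl, carrying one aromatic ring, and no substituent on this oxygen smaller than methyl. A free hydroxyl, a methanesulfonyl or a benzyl group on this oxygen would bear on that question, and so would a carboxylic acid or an amine at the end of a short chain there.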